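Notes on one chain substitution in a small series

A few compounds are considered here, and "the series" means these few. Any claim that something is new, unique, unknown or untested is made for them only; others in the source may bear on it.

Values in a functional assay on SW480 cells (Homo sapiens) for antiproliferative activity, read by MTT assay, with a stated time of 48 h (on this read-out higher numbers stand for weaker inhibition and lower numbers for stronger inhibition), for the series:
Compound 1 `CC(C)=CCC[C@]1(C)/C=C/[C@@H](OC(=O)C=C(C)C)[C@](C)(O)/C=C/C(=O)/C(CN2CCN(C)CC2)=C\C1` gives 800 nM
Compound 2 `CC[Si](CC)(CC)C/C1=C/C[C@](C)(CCC=C(C)C)/C=C/[C@@H](OC(=O)C=C(C)C)[C@](C)(O)/C=C/C1=O` gives 2690 nM

Compound 2 stands highest of the two numbers. The structural change to compound 3 `CC(C)=CCC[C@]1(C)/C=C/[C@@H](OC(=O)C=C(C)C)[C@](C)(O)/C=C/C(=O)/C(COC(=O)c2ccc([N+](=O)[O-])cc2)=C\C1` is a group of 12 heavy atoms (7 carbon, 1 nitrogen, 4 oxygen; one six-membered aromatic ring of carbon only) in place of a group of 7 heavy atoms (6 carbon, 1 silicon; no ring), on a saturated chain carbon bound to a double-bonded ring carbon and sits on a saturated chain carbon bound to a double-bonded ring carbon. Within the data shown here, the one measured step at that place is a 3.4-fold higher number from compound 1 to compound 2 (0.53 log units; beyond the scatter) and involves a different group, so it offers a size only. A modest step to a lower number is therefore expected in this assay and no larger than that one. The expected step is a 2.2-fold lower number from compound 2 to compound 3 (0.35 log units; beyond the scatter) and remains an estimate. Compound 3 is estimated at 1200 nM (expected range 400 nM to 3600 nM).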

Compound 3, half-maximal inhibitory concentration: 570 nM
Compound 3: the middle estimate sits 2.1-fold (0.32 log units) above what was measured, and the stated range covers the measured number.
By their numbers in this assay, from the lowest: compounds 3 and 1 (each within the scatter of the next); then compound 2.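

In this assay the ((4-nitrophenyl)carbonyl)oxy group on this saturated chain carbon brings a 4.7-fold lower number from compound 2 to compound 3 (0.67 log units; beyond the scatter) and so gives a second step beyond the scatter away from compound 2. With a 1.4-fold lower number from compound 1 to compound 3 (0.15 log units; within the scatter) as the other new step, ((4-nitrophenyl)carbonyl)oxy and 4-methylpiperazin-1-yl cannot be told apart here, although they differ in ring and heavy-atom count, and only the silicon-bearing group stands apart. No measurement offered here explains this.

Going by these compounds, whether a primary amine, a carboxylic acid or a longer alkyl chain would match these two groups stays open. So does the part played by the nitro group in compound 3.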